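Removing a methoxy from compound 1

This account rests on a few compounds, and the source may have more. Where it says the series, first, only, none or still open, it means among the compounds named here.

Values measured in a functional assay on HCT-116 cells (Homo sapiens) for inhibition, read by colorimetric assay, with a stated time of 3 days (a higher number here means a weaker inhibitor, a lower number a stronger inhibitor), for three compounds
- compound 1 (`COc1ccc(-c2cnc(NC(=O)CCCCCCNC(=O)C(O)(O)C(F)(F)F)s2)cc1`) gives 930 nM
- compound 2 (`O=C(CCCCCCNC(=O)c1cc(=O)c(O)co1)Nc1ccccc1`) gives > 100000 nM as a limit of the assay
- compound 3 (`COc1ccccc1NC(=O)CCCCCCNC(=O)C(O)(O)C(F)(F)F`) gives 10100 nM

Only two of these three results are actual numbers. Compound 1 at 930 nM has the lower of them and is the stronger inhibitor when set against compound 3 at 10100 nM in a gap that lies beyond the usual scatter. Compound 2 gives only a limit and no number.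

Compound 4 (`O=C(CCCCCCNC(=O)C(O)(O)C(F)(F)F)Nc1ncc(-c2ccccc2)s1`) has not yet been measured. It differs from compound 1 in one place (hydrogen in place of methoxy on an aromatic carbon) with hydrogen in place of methoxy on an aromatic carbon of a six-membered aromatic ring of carbon only, para to a large group. The same difference reads 4-methoxyphenyl to phenyl. Within the data shown here, no pair of measured compounds shows this change on its own, and the expectation therefore starts from compound 1 at 930 nM as its reference point. The change is expected to leave the result in this assay within the scatter, with an estimated step (a 1.2-fold higher number from compound 1 to compound 4 (0.07 log units; within the scatter)) that leans only slightly towards a weaker inhibitor. For compound 4 the estimated value is 1100 nM (expected range 350 nM to 3500 nM).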

Compound 4, half-maximal inhibitory concentration: 2660 nM
The estimate for compound 4 lay 2.4-fold (0.38 log units) below the measured number, within the range that was stated.
By their numbers in this assay, from the lowest: compound 1; then compound 4; then compound 3. At a limit, above all of these: compound 2.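

In this assay, hydrogen in place of methoxy on an aromatic carbon, para to a large group, moves the result towards a weaker inhibitor in a modest step (a 2.9-fold higher number from compound 1 to compound 4 (0.46 log units; beyond the scatter)) that lies beyond the scatter. The earlier compounds shown here could not show this, as no two of them formed a pair differing in this one place, so the contribution of the methoxy at this position had not been read directly. The step also shows that the 4-methoxyphenyl group is not needed for a measurable result, since compound 4 with its phenyl group still gives a number (2660 nM), although the methoxy does favour a stronger inhibitor in this pair.

A single pair cannot show whether the gain is particular to methoxy, and a hydroxyl group, an amine or a fluorine atom at the same place on this ring would each test that in a different way. The compounds shown offer no measurement that accounts for the size or the direction of this step.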